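The source may report more compounds than this note shows. Statements on the series, on what has been measured and on what is new or still open speak of the compounds shown alone.

Working notes on the series.

In a functional assay on HEp-2 cells (Homo sapiens) for antiproliferative activity, read by MTT assay, with a stated time of 72 h (a lower number here means a stronger inhibitor, a higher number a weaker inhibitor), compound 3 `O=c1c(Cl)c(CSC(=S)N2CCCC2)oc2ccccc12` gives 600 nM, while compound 1 `CC(C)N(C(=S)SCc1oc2ccccc2c(=O)c1Cl)C(C)C` gives 20000 nM. The change between them is diisopropylamino in place of pyrrolidin-1-yl on a thiocarbonyl carbon, and the step it made is a 33-fold higher number from compound 3 to compound 1 (1.52 log units; beyond the scatter). Compound 2 `Cc1ccc2c(=O)c(CSC(=S)N3CCCC3)coc2c1` carries a different core; how its core differs from that of compound 3 is not broken down here, and in this assay compound 2 gives 3600 nM, between the other two values with both steps beyond the scatter.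

Compound 4 `Cc1ccc2c(=O)c(CSC(=S)N(C(C)C)C(C)C)coc2c1` is not yet measured. Going by the values given here, it is reached from compound 2 by diisopropylamino in place of pyrrolidin-1-yl on a thiocarbonyl carbon, which is the same change as the one from compound 3 to compound 1, at the same place. Among the compounds with values here, the only measured instance of this change is the large loss recorded as a 33-fold higher number from compound 3 to compound 1 (1.52 log units; beyond the scatter), and that single pair is the only basis for what follows. A step of similar direction is expected from compound 2 to compound 4, a 17-fold higher number from compound 2 to compound 4 (1.22 log units; beyond the scatter), though with one prior example and a different core its size is uncertain. On that basis compound 4 is estimated to give about 60000 nM in this assay, plausibly between 15000 nM and 200000 nM.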

Compound 4, half-maximal inhibitory concentration: 700 nM
Beside the measured number, compound 4's estimate is 86-fold (1.93 log units) above it, and the stated range ends above it.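

In this assay, diisopropylamino in place of pyrrolidin-1-yl on a thiocarbonyl carbon gives a 5.1-fold lower number from compound 2 to compound 4 (0.71 log units; beyond the scatter), so the direction of the earlier step is reversed and the two steps clearly differ: the same change on two cores in this assay, a 33-fold higher number (1.52 log units; beyond the scatter) from compound 3 to compound 1 and a 5.1-fold lower number (0.71 log units; beyond the scatter) from compound 2 to compound 4, 170-fold (2.23 log units) apart, beyond the scatter of two such steps

The result from one core therefore cannot be carried over to the other, in either size or direction, and a single pair is a poor guide to this change anywhere in the series. Going by these compounds alone, the two pairs do not show which feature of the cores lies behind the reversal, nor which direction would be the more usual one, since each core supplies only one pair.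

From the compounds shown here alone, it remains open whether other amines on the thiocarbonyl carbon, such as diethylamino or piperidin-1-yl, would follow compound 1 or compound 4 on each core. Going by these compounds, it is also open how this change would behave on a further core, for example one carrying a methoxy group.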